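Compound 3 to compound 4: a step from a limit

The source may hold more compounds than are shown below. What is called first, only, known or untested is meant among the compounds shown, and "the series" means these compounds.

Compound 1 `CCOCCNC(=O)n1cc(-c2ccccc2)oc1=O`: 20000 nM
Compound 2 `COc1cccc(-c2cn(C(=O)NCCCCc3ccccc3)c(=O)o2)c1`: < 1000 nM, a limit
Compound 3 `COc1cc(-c2cn(C(=O)NCCCCc3ccccc3)c(=O)o2)ccc1F`: < 1000 nM, a limit
Compound 4 `O=C(NCCCCc1ccccc1)n1cc(-c2ccncc2)oc1=O`: not yet measured

All three measured compounds were tested in a physicochemical assay for solubility, read by HPLC, in phosphate buffer, measured as kinetic solubility, with a stated time of 1 h, at pH 7.4, tested at 250 uM; a higher number here means a more soluble compound, a lower number a less soluble compound. Compound 3 stands at < 1000 nM, which is a limit of the assay and not a number. Compound 2 also gives only a limit, < 1000 nM. Going by the values given here, compound 1, at 20000 nM, is the only one with a real number. The evidence so far is therefore thin: the limit of < 1000 nM in this assay, at which 2 of the 3 values shown sit.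

The next compound makes one structural change, on an aromatic carbon of a five-membered aromatic ring with 1 nitrogen and 1 oxygen: pyridin-4-yl in place of 4-fluoro-3-methoxyphenyl on an aromatic carbon. Among the compounds with values here, the only measured step between two closely related compounds is a step that the two limits leave unreadable from compound 2 to compound 3. Within the data shown here, that step is a fluoro in place of hydrogen on an aromatic carbon, so it gives no size to carry over, and no measured step makes this exchange of groups. Any forecast is therefore a cautious judgement. The value of compound 1, 20000 nM, shows that this assay can return a real number. A modest upward move is expected, estimated as an at least 2.0-fold higher number from compound 3 to compound 4 (0.30 log units; that floor lies within the scatter). For compound 4 the expected value is 2000 nM, with an estimated range from 500 nM to 15000 nM.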

Compound 4, solubility: < 1000 nM
Compound 4: no number, only a limit (the forecaster's own chance of this, stated with the estimate: 40%); middle value at least 2.0-fold (0.30 log units) away from the limit.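

In this assay compound 4 gives < 1000 nM, which is a limit of the assay and not a number. The steps linking compound 2, compound 3 and compound 4 cannot be read, since each of these compounds gives only a limit. The compounds shown leave open how these three truly compare, as the evidence rests on one limit: the limit of < 1000 nM in this assay, at which 3 of the 4 values shown sit.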